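Swapping pyridinyl for phenyl on a weakly cytotoxic core

The source may report more compounds than this note shows. Statements on the series, on what has been measured and on what is new or still open speak of the compounds shown alone.

Compounds measured so far:
compound 1, `Oc1cccc(-c2cc(-c3cccnc3)nc(-c3cccc(Cl)c3)c2)c1`, "not determined" (no result reported);
compound 2, `Oc1cccc(-c2cc(-c3cccnc3)nc(-c3ccccc3Cl)c2)c1`, "not determined" (no result reported);
compound 3, `Oc1cccc(-c2cc(-c3ccc(Cl)cc3)nc(-c3cccnc3)c2)c1`, 16800 nM.

Within the data shown here, compound 1 and compound 2 carry no number in a functional assay on HCT-15 cells (Homo sapiens) for cytotoxicity, read by CCK-8 assay and cell counting, with a stated time of 2 days (on this read-out lower numbers stand for stronger inhibition and higher numbers for weaker inhibition), so compound 3 stands alone as the only compound with a result in this assay, and its value is a weak one. Compound 4, `Oc1cccc(-c2cc(-c3ccccc3)nc(-c3ccc(Cl)cc3)c2)c1`, differs from compound 3 by phenyl in place of pyridin-3-yl on an aromatic carbon. Among the measured compounds shown here, with no measured step of this kind to lean on, the change is expected to move the read-out little, if at all, beyond the usual scatter. The step from compound 3 to compound 4 is therefore estimated as a 1.1-fold lower number from compound 3 to compound 4 (0.05 log units; within the scatter). For compound 4 the expected value in this assay is 15000 nM, with a range from 5000 nM to 50000 nM.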

Compound 4, half-maximal inhibitory concentration: 8110 nM
For compound 4 the middle estimate is 1.8-fold (0.27 log units) above the measured one; low and high end bracket the measured number.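

In this assay, among these compounds, phenyl in place of pyridin-3-yl gives a 2.1-fold lower number from compound 3 to compound 4 (0.32 log units; beyond the scatter), the first step that can be read on this core. It shows that the position next to the ring nitrogen responds to this change, if only modestly, and that a number is still obtained without the pyridine nitrogen of compound 3. Nothing shown here bears on why the number moves. Going by these compounds, whether an amine or a methoxy group on this phenyl would shift the number further remains open. So does the effect of a saturated piperidine ring at this position.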